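The source may hold more compounds than are shown below. What is called first, only, known or untested is meant among the compounds shown, and "the series" means these compounds.

Measured so far in a functional assay on HFF cells (Homo sapiens) for cytotoxicity, read by neutral red uptake; on this read-out lower numbers stand for higher toxicity in this test and higher numbers for lower toxicity in this test
compound 1 `CCOC(OCC)c1cn(C2C[C@H](OC(C)=O)[C@@H](COC(C)=O)O2)c(=O)[nH]c1=O` gives > 300000 nM as a limit
compound 2 `CCOC(OCC)c1cn(C2C[C@H](O)[C@@H](CO)O2)c(=O)[nH]c1=O` gives > 300000 nM as a limit

Compound 2 stands at > 300000 nM as a limit of the assay and not a number. Compound 1 gives > 300000 nM as a limit too. Among the measured compounds shown here, the series so far sits at the limit of > 300000 nM in this assay, at which 2 of the 2 values shown sit, and offers no measured step to scale from.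

The next compound is compound 3 `O=c1[nH]c(=O)n(C2C[C@H](O)[C@@H](CO)O2)cc1C1OCCCO1` and its difference from compound 2 is this one a group of 6 heavy atoms (4 carbon, 2 oxygen; one six-membered non-aromatic ring with 2 hetero atoms) in place of a group of 7 heavy atoms (5 carbon, 2 oxygen; no ring), on an aromatic carbon on an aromatic carbon. Diethoxymethyl leaves, and a group with one six-membered non-aromatic ring with 2 hetero atoms enters.

The expectation rests on compound 2 and its > 300000 nM as a limit of the assay. In this assay no change beyond the usual scatter is expected, and the estimated step of a number no higher from compound 2 to compound 3 (the limit leaves the size open) has no clear direction. A reading of compound 3 as a limit again is the likeliest outcome. The expected value for compound 3 is 300000 nM with an estimated range of 100000 nM to 500000 nM for a numerical reading.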

Compound 3, half-maximal cytotoxic concentration: > 300000 nM
Compound 3: no number, only a limit; the forecaster's own chance of this, stated with the estimate: 80%; the middle value sits exactly at the limit.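

In this assay compound 3 gives > 300000 nM, a limit of the assay and not a number. Compound 2 also sits at a limit, and no step can be read from compound 2 to compound 3. The compounds shown leave open whether replacing diethoxymethyl changes toxicity in this assay, and what numerical value any compound would give: the limit of > 300000 nM in this assay, at which 3 of the 3 values shown sit.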